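Methyl for fluoro on the ethyl compound

This account rests on a few compounds, and the source may have more. Where it says the series, first, only, none or still open, it means among the compounds named here.

In a functional assay on HGC cells (Homo sapiens) for cytotoxicity, read by MTT assay, with a stated time of 48 h (a lower number here means a stronger inhibitor, a higher number a weaker inhibitor), compound 2 (`CCn1c(/C=C2/C(=O)Nc3ccc(F)cc32)nc2ccccc21`) gives > 50000 nM as a limit of the assay and not a number. Among the compounds with values here, the change to compound 4 (`CCn1c(/C=C2/C(=O)Nc3ccc(C)cc32)nc2ccccc21`) is methyl in place of fluoro on an aromatic carbon with methyl in place of fluoro on an aromatic carbon, a swap that no measured pair makes. In this assay compound 1 (`CC(C)n1c(/C=C2/C(=O)Nc3ccc(Br)cc32)nc2ccccc21`) gives 12400 nM and compound 3 (`CC(C)n1c(/C=C2/C(=O)Nc3ccc(F)cc32)nc2ccccc21`) gives 28000 nM with fluoro in place of bromo. Replacing fluoro is expected to bring only a modest drop, since the halogen change gives a 2.3-fold higher number from compound 1 to compound 3 (0.35 log units; beyond the scatter) as the nearest guide and the chain change gives an at least 1.7-fold lower number from compound 2 to compound 3 (0.25 log units; that floor lies within the scatter) as a weaker one. The expected move is an at least 1.2-fold lower number from compound 2 to compound 4 (0.09 log units; that floor lies within the scatter) on this estimate. Compound 4 is estimated at 40000 nM with an expected range from 18000 nM to 90000 nM and a reading at the limit remains possible.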

Compound 4, half-maximal inhibitory concentration: > 50000 nM
Compound 4 gave a limit, no number (the forecaster's own chance of this, stated with the estimate: 40%); middle value at least 1.2-fold (0.09 log units) away from the limit.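

Compound 2 and compound 4 both stand at a limit, not a number, in this assay, so no step between them can be read: the limit of > 50000 nM in this assay, at which 2 of the 4 values shown sit.

The compounds shown leave open how methyl compares with fluoro on an aromatic carbon.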